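Quinoxaline diamines: benzyl amine swap and cell toxicity

The compounds below may be only part of what the source reports. "The series", "measured", "known", "first", "only" and "open" are said of these compounds alone.

Measured so far:
Compound 1 `Nc1cc(N)c2nc(-c3ccccc3)c(NCc3ccc(Cl)c(Cl)c3)nc2c1`: 66100 nM
Compound 2 `CCOC(=O)[C@H](CCC(=O)O)NC(=O)c1ccc(Oc2nc3cc(N)cc(N)c3nc2-c2ccccc2)cc1`: < 100000 nM

Among the compounds with values here, in a functional assay on COLO 205 cells (Homo sapiens) for inhibition, read by sulforhodamine B assay, with a stated time of 48 h (on this read-out higher numbers stand for lower toxicity in this test and lower numbers for higher toxicity in this test), compound 1 gives 66100 nM and is the only compound with a number rather than a limit. Compound 2 reaches only a limit in this assay, < 100000 nM; this is reflected in the limit of < 100000 nM in this assay, at which 1 of the 2 values shown sits. Compound 3 `COc1ccc(CNc2nc3cc(N)cc(N)c3nc2-c2ccccc2)cc1` is not yet measured. It differs from compound 1 by 4-methoxyphenyl in place of 3,4-dichlorophenyl on a saturated chain carbon bound to a nitrogen on an aromatic ring. Within the data shown here, no measured step resembles this change, so the step is expected to be modest, a 1.1-fold higher number from compound 1 to compound 3 (0.05 log units; within the scatter), with no clear direction beyond the scatter. Compound 3 is therefore estimated at 75000 nM, between 30000 nM and 150000 nM.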

Compound 3, concentration lethal to 50% of the cells: 74100 nM
Compound 3: middle estimate off by 1.0-fold (0.01 log units), on the high side; low and high end bracket the measured number.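

In this assay, within the data shown here, the change from 3,4-dichlorobenzyl to 4-methoxybenzyl gives the only readable step at this place: a 1.1-fold higher number from compound 1 to compound 3 (0.05 log units; within the scatter). On a saturated chain carbon bound to a nitrogen on an aromatic ring, the two substituted phenyl groups therefore cannot be told apart in this read-out. Compound 2 remains a limit and adds no step: the limit of < 100000 nM in this assay, at which 1 of the 3 values shown sits.

The compounds shown leave open whether an amine or a carboxylic acid in place of the methoxy group, or a longer chain at this place, would give a step beyond the scatter.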